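Working notes: from compound 1 to compound 4

A few compounds are considered here, and "the series" means these few. Any claim that something is new, unique, unknown or untested is made for them only; others in the source may bear on it.

Going by the values given here, in a functional assay on HL-60 cells (Homo sapiens) for inhibition, read by CCK-8 assay, with a stated time of 48 h (on this read-out lower numbers stand for stronger inhibition and higher numbers for weaker inhibition), compound 1 `O=S(=O)(NCCNC(=S)Nc1cccc(Cl)c1)c1ccc(-c2ccccc2OCc2cccc(O)c2)s1` gives 1800 nM, the lowest of the two numbers so far. Compound 3 `O=C(Nc1cccc([N+](=O)[O-])c1)N1CCN(S(=O)(=O)c2sccc2-c2ccccc2Oc2ccc(O)c(O)c2)CC1` gives 4500 nM, a higher number by more than the usual scatter. Compound 2 `COc1ccc(NC(=O)NCCNS(=O)(=O)c2ccc(-c3ccccc3OCc3ccccc3)s2)cc1` is reported only as a limit, > 50000 nM.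

Compound 4 `O=C(NCCNS(=O)(=O)c1ccc(-c2ccccc2OCc2cccc(O)c2)s1)Nc1cc(Cl)cc(Cl)c1` keeps the core of compound 1 and changes one place, on an amine nitrogen: a group of 11 heavy atoms (7 carbon, 1 nitrogen, 1 oxygen, 2 chlorine; one six-membered aromatic ring of carbon only) in place of a group of 10 heavy atoms (7 carbon, 1 nitrogen, 1 sulfur, 1 chlorine; one six-membered aromatic ring of carbon only), on an amine nitrogen. The entering group is (3,5-dichlorophenyl)carbamoyl, which carries a carbonyl where compound 1 has none.

Among the compounds with values here, no measured pair isolates this change, so the expectation is only loosely anchored. Compound 3 also carries a carbonyl in its corresponding group, and at 4500 nM it offers the nearest numerical guide, although it differs from compound 1 in several places. Compound 2 also carries a carbonyl, and its limit leaves a wide upper side open. A modest move toward weaker inhibition is therefore expected in this assay, with a real chance that it stays within the scatter. The estimated change is a 2.2-fold higher number from compound 1 to compound 4 (0.35 log units; beyond the scatter). For compound 4 the expected value is 4000 nM, with an estimated range from 1000 nM to 20000 nM.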

Compound 4, half-maximal inhibitory concentration: 2800 nM
Estimate against measurement, compound 4: 1.4-fold (0.15 log units) above; the measured number falls inside the stated range.
By their numbers in this assay, from the lowest: compounds 1, 4 and 3 (each within the scatter of the next, the first and the last beyond it). At a limit, above all of these: compound 2.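

In this assay, the series now has its first comparison that differs in one place: a 1.6-fold higher number from compound 1 to compound 4 (0.19 log units; within the scatter). At this amine nitrogen, (3,5-dichlorophenyl)carbamoyl can therefore stand in place of the sulfur-bearing group of compound 1 without a change that can be read on this assay, even though the entering group carries a carbonyl and one more chlorine. No measurement shown bears on why compound 1 and compound 4 lie within the scatter of each other.

Going by these compounds alone, the single step changes sulfur to oxygen and the chlorine count together, so what each contributes alone remains open, as does the response of this amine nitrogen to a group with no aromatic ring, such as acetyl or a longer alkyl chain. Also open, as far as these compounds go, is whether a carboxylic acid or an amine on the ring of the entering group would leave the number close to that of compound 4, at 2800 nM.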